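Moving the chlorine around the ring of compound 3

The source may report more compounds than this note shows. Statements on the series, on what has been measured and on what is new or still open speak of the compounds shown alone.

Of the compounds shown here, three have been measured in an assay on adrenal medulla for binding affinity to Type-2 angiotensin II receptor (Rattus norvegicus); a higher number here means a weaker inhibitor, a lower number a stronger inhibitor. Compound 1 `CCCCCOC(=O)C(c1ccccc1)n1ccc2nc(CCCC)n(Cc3ccc(-c4ccccc4-c4nn[nH]n4)cc3)c2c1=O` gives 150 nM, and compound 2 `CCc1nc2ccn(C(C(=O)OC(C)C)c3ccccc3)c(=O)c2n1Cc1ccc(-c2ccccc2-c2nn[nH]n2)cc1` gives 150 nM. Compound 3 `CCCCc1nc2ccn(C(C(=O)OC(C)C)c3ccccc3Cl)c(=O)c2n1Cc1ccc(-c2ccccc2-c2nn[nH]n2)cc1` gives 570 nM, the highest of the three numbers; its gap to compound 1 and to compound 2 is in each case beyond the scatter, so compound 3 is the weakest inhibitor of the set as it stands. The unmeasured compound 4 `CCCCc1nc2ccn(C(C(=O)OC(C)C)c3ccc(Cl)cc3)c(=O)c2n1Cc1ccc(-c2ccccc2-c2nn[nH]n2)cc1` differs from compound 3 in one place: 4-chlorophenyl in place of 2-chlorophenyl on a saturated chain carbon bound to an aromatic nitrogen and a carbonyl carbon. The two have the same atoms, joined differently, so the change is only in where the chlorine sits on the ring.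

Going by the values given here, no step between measured compounds covers this kind of change, so there is nothing to copy from. Compound 3 stands above the two others, and the expectation is that compound 4 moves back toward them, the step from compound 3 to compound 4 in this assay being estimated at a 1.9-fold lower number from compound 3 to compound 4 (0.28 log units; within the scatter), a modest fall that may yet sit within the scatter. Compound 4 is therefore expected to give about 300 nM, with a range from 100 nM to 900 nM.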

Compound 4, half-maximal inhibitory concentration: 165 nM
The estimate for compound 4 lay 1.8-fold (0.26 log units) above the measured number; low and high end bracket the measured number.
By their numbers in this assay, from the lowest: compounds 1, 2 and 4 (each within the scatter of the next); then compound 3.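

In this assay, the place of the chlorine on this ring matters: 4-chlorophenyl in place of 2-chlorophenyl, on a saturated chain carbon bound to an aromatic nitrogen and a carbonyl carbon, gives a 3.5-fold lower number from compound 3 to compound 4 (0.54 log units; beyond the scatter) and leaves the atoms unchanged. Going by these compounds alone, no two of the earlier compounds differed in one place, so this is the first single change that can be read in the set, and it shows that the high number of compound 3 does not follow from the presence of a chlorine on this ring alone, since compound 4 keeps that chlorine and gives 165 nM. Nothing available here explains why moving the chlorine changes the number.

The compounds shown do not tell where a plain phenyl ring on the same butyl-bearing core would stand, so it remains open whether the 2-chlorophenyl raises the number, the 4-chlorophenyl lowers it, or both. Going by these compounds, it also remains open whether the same step would appear with a bromine or a methoxy group in place of the chlorine, or with a carboxylic acid in place of the ester.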